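Swapping methoxy for trifluoromethyl on the pendant ring

The source may hold more compounds than are shown below. What is called first, only, known or untested is meant among the compounds shown, and "the series" means these compounds.

Of the compounds shown here, three sharing one core have been measured in an assay on CHO cells for displacement of a labelled ligand from adenosine receptor A3 (Homo sapiens), read by scintillation counting, with a stated time of 120 min, tested at 1 uM; on this read-out higher numbers stand for more inhibition at the one concentration tested (going by the name of the read-out) and lower numbers for less inhibition. Going by the values given here, compound 1 `Cc1nc2sc(-c3ccc(C(F)(F)F)cc3)nc2c(=O)[nH]1` gives 32% in this assay, and compound 2 `Cc1nc2sc(-c3ccc(C(=O)O)cc3)nc2c(=O)[nH]1` gives 1%; the one recorded step, a number 31 percentage points lower from compound 1 to compound 2 (beyond the scatter), shows that a carboxy group in place of trifluoromethyl at that position loses most of the inhibition. Compound 3 `COc1cccc(-c2nc3c(=O)[nH]c(C)nc3s2)c1` gives 28%, the second highest of the three numbers; its value sits within the scatter of compound 1 and well beyond the scatter of compound 2.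

Compound 4 `Cc1nc2sc(-c3cccc(C(F)(F)F)c3)nc2c(=O)[nH]1` has not yet been measured. It differs from compound 3 by trifluoromethyl in place of methoxy on an aromatic carbon. Among the compounds with values here, no measured step covers this particular exchange: the only step known changes trifluoromethyl to carboxy, not methoxy to trifluoromethyl, so it bears on the question only indirectly, by showing that trifluoromethyl on that ring is compatible with inhibition in compound 1 at 32%. Since compound 1 with trifluoromethyl and compound 3 with methoxy give numbers within the scatter of each other, the expected step of a number 2 percentage points higher from compound 3 to compound 4 (within the scatter) is small, with no clear direction. Compound 4 is therefore estimated at 30%, with a range from 15% to 45%.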

Compound 4, a percentage reported as inhibition, at one concentration (the size of the read-out at that concentration, not a potency): 15%
The estimate for compound 4 lay 15 percentage points above the measured number, within the range that was stated.
By their numbers in this assay, from the lowest: compound 2; then compound 4; then compounds 3 and 1 (each within the scatter of the next).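

Trifluoromethyl in place of methoxy on an aromatic carbon, meta to a large group, proves not to be a neutral exchange in this assay: there is a number 13 percentage points lower from compound 3 to compound 4 (beyond the scatter) and so, at this place, methoxy goes with more inhibition than trifluoromethyl. Until now trifluoromethyl had been seen only at another place on the ring, where compound 1 gives 32% in this test, while compound 4 gives 15% here, so what a group does at one place on this ring cannot simply be carried over to the other. Nothing available bears on what lies behind this step.

The compounds shown leave open how other groups at this place would read, such as ethoxy, a longer chain or an amine, and whether any of them would exceed methoxy. They also leave open how far these numbers reflect potency, since each comes from a single concentration, and how methoxy would read at the place that trifluoromethyl holds in compound 1.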